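The compounds below may be only part of what the source reports. "The series", "measured", "known", "first", "only" and "open" are said of these compounds alone.

Compound 1 `CCCC(C)(C)Nc1ccc(NC(=O)c2cc(Cl)ccc2O)c(Cl)c1` — 23700 nM in an ADME assay on A549 cells (Homo sapiens) for cytotoxicity, read by LDH release, with a stated time of 15 h; a higher number here means that more compound is tolerated, a lower number that less compound is tolerated
Compound 2 `CC(=O)Nc1ccc(NC(=O)c2cc(Cl)ccc2O)c(Cl)c1` — "not determined" (no result reported) in this assay

Compound 2 stands without a number in this assay; only compound 1 carries a value there. Compound 3 `CC(C)Nc1ccc(NC(=O)c2cc(Cl)ccc2O)c(Cl)c1` follows from compound 2 by one change: isopropyl in place of acetyl on a nitrogen on an aromatic ring. Going by the values given here, with no measured pair to anchor a step, no direction beyond the usual scatter is assumed for this change in this assay, and compound 1 supplies the only reference point. Compound 3 is therefore estimated to lie near 30000 nM in this assay, within a range from 10000 nM to 100000 nM.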

Compound 3, half-maximal cytotoxic concentration: 82700 nM
The estimate for compound 3 lay 2.8-fold (0.44 log units) below the measured number, and the stated range covers the measured number.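

Going by these compounds alone, on the nitrogen on an aromatic ring, this assay now gives a first readable step between two alkyl groups: hydrogen in place of propyl on the saturated chain carbon brings a 3.5-fold higher number from compound 1 to compound 3 (0.54 log units; beyond the scatter) and more compound is tolerated. The change from acetyl to isopropyl itself cannot be read, as compound 2 has no number. No measured finding accounts for the step.

The compounds shown leave open how this assay reads with a cyclopropyl group or an unbranched ethyl chain on this nitrogen. They also leave open whether a carboxylic acid on the chain would fit the same trend.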